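The source may report more compounds than this note shows. Statements on the series, on what has been measured and on what is new or still open speak of the compounds shown alone.

Working notes on the series. Within the data shown here, in a functional assay on MGC-803 cells (Homo sapiens) for cytotoxicity, read by MTT assay, with a stated time of 48 h (on this read-out higher numbers stand for weaker inhibition and lower numbers for stronger inhibition), compound 2 `CC(=O)Oc1ccccc1C1CC(C)=NN1C(=O)CN(C(C)C)C(C)C` gives 20100 nM and holds the lower of the two numbers so far. Compound 1 `CC1=NN(C(=O)c2ccc(C)cc2)C(c2cc(Br)cc(Br)c2O)C1` stands higher at 56500 nM in the same read-out, a gap beyond the scatter. Compound 3 `CC(=O)Oc1ccccc1C1CC(C)=NN1C(=O)CCl` has not yet been measured. It carries chloro in place of diisopropylamino on a saturated chain carbon bound to a carbonyl carbon, and the counted difference reads chloro in place of diisopropylamino on a saturated chain carbon bound to a carbonyl carbon for this exchange. Among the measured compounds shown here, no measured pair isolates this change, so the only anchor is compound 2 at 20100 nM in this assay and the uncertainty is wide. The expected change is a 1.4-fold lower number from compound 2 to compound 3 (0.16 log units; within the scatter) in the number, a modest move toward stronger inhibition that is not expected to exceed the scatter. The estimate for compound 3 is 14000 nM as the central value, with 4500 nM to 45000 nM as the expected range.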

Compound 3, half-maximal inhibitory concentration: 3010 nM
Estimate against measurement, compound 3: 4.7-fold (0.67 log units) above; the whole stated range lies above it.
By their numbers in this assay, from the lowest: compound 3; then compound 2; then compound 1.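

In this assay, among these compounds, the saturated chain carbon bound to a carbonyl carbon is the first place where a single exchange can be read, and it responds to its substituent: chloro in place of diisopropylamino gives a 6.7-fold lower number from compound 2 to compound 3 (0.82 log units; beyond the scatter) on the shared core. The diisopropylamino group, with its 7 heavy atoms, is therefore not needed at this place for a low number on this read-out, since a single chlorine atom gives a lower one. Nothing at hand explains why the number moves with this exchange.

Only these two groups are shown at this place, so it remains open whether the step follows from the arrival of chloro or from the departure of diisopropylamino. Bromo, hydroxyl or dimethylamino on the same carbon would help to separate these two readings.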